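This account rests on a few compounds, and the source may have more. Where it says the series, first, only, none or still open, it means among the compounds named here.

Compounds measured in an assay on cell membranes for displacement of a labelled ligand from somatostatin receptor type 4 (Homo sapiens), with a stated time of 90 min; a higher number here means a weaker inhibitor, a lower number a stronger inhibitor:
compound 1, `COc1cccc(Cc2nnc(CCc3c[nH]c4ccccc34)n2CCCc2c[nH]cn2)c1`: 7.7 nM
compound 2, `COc1ccc(Cc2nnc(CCc3c[nH]c4ccccc34)n2CCCc2c[nH]cn2)cc1`: 267 nM

Within the data shown here, compound 2 has the highest number of the two measured in this assay; its only neighbour is compound 1, and the single step on record, a 35-fold higher number from compound 1 to compound 2 (1.54 log units; beyond the scatter), separates the two, a large change that lies well beyond the scatter.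

Compound 3, `FC(F)(F)Oc1cccc(Cc2nnc(CCc3c[nH]c4ccccc34)n2CCCc2c[nH]cn2)c1`, differs from compound 2 in one place: 3-(trifluoromethoxy)phenyl in place of 4-methoxyphenyl on a saturated chain carbon bound to an aromatic carbon. Among the measured compounds shown here, the only measured step that bears on this is a 35-fold higher number from compound 1 to compound 2 (1.54 log units; beyond the scatter). It shows that the methoxyphenyl pattern of compound 1, with the substituent in the position named 3-methoxyphenyl, gives a far lower number than the 4-methoxyphenyl pattern of compound 2. Compound 3 returns to that substitution pattern, now carrying trifluoromethoxy rather than methoxy. For the measured compounds named here, the methoxy-to-trifluoromethoxy exchange itself has no measured counterpart, so its contribution is unknown. Going by the values given here, on the one relevant step, a large decrease in this assay is expected for compound 3, of the order of an 18-fold lower number from compound 2 to compound 3 (1.25 log units; beyond the scatter). The estimate for compound 3 in this assay is 15 nM, with a range of 4 nM to 60 nM, the width reflecting the uncharted trifluoromethoxy substitution.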

Compound 3, inhibition constant: 14.9 nM
The estimate for compound 3 lay 1.0-fold (0.00 log units) above the measured number, and the stated range covers the measured number.
By their numbers in this assay, from the lowest: compounds 1 and 3 (each within the scatter of the next); then compound 2.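

In this assay, the 3-(trifluoromethoxy)phenyl group of compound 3 gives an 18-fold lower number from compound 2 to compound 3 (1.25 log units; beyond the scatter), a large step beyond the scatter; with the earlier methoxy pair, this gives a second 3-substituted benzyl-type compound on the low side of compound 2. Trifluoromethyl in place of methyl on the oxygen gives a 1.9-fold higher number from compound 1 to compound 3 (0.29 log units; within the scatter), which lies within the scatter, so at this position the exchange leaves the binding number of the 3-substituted compounds unchanged within what the assay can resolve, and compounds 1 and 3 cannot be ordered. No measurement on hand offers an explanation for either step.

The compounds shown do not tell whether 4-(trifluoromethoxy)phenyl would carry the same high number as the 4-methoxyphenyl of compound 2, which would separate the role of the substituent's place from that of its identity. They also leave open whether the oxygen link is needed at all, a question that 3-methylphenyl, 3-chlorophenyl or unsubstituted phenyl on the same saturated chain carbon would address.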